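The source may report more compounds than this note shows. Statements on the series, on what has been measured and on what is new or still open speak of the compounds shown alone.

Measured so far in a functional assay on MIA PaCa-2 cells (Homo sapiens) for cytotoxicity, read by MTT assay, with a stated time of 72 h; on this read-out lower numbers stand for an effect already at smaller amounts and higher numbers for an effect only at larger amounts of compound:
- compound 1 `O=C1/C(=C\c2cccc(Oc3ccccc3)c2)c2ccccc2N1c1c(Cl)cccc1Cl`: > 100 ug/mL, a limit of the assay
- compound 2 `O=C1/C(=C\c2ccc(F)cc2)c2ccccc2N1c1c(Cl)cccc1Cl`: 5 ug/mL
- compound 3 `O=C1/C(=C\c2ccc(O)cc2)c2ccccc2N1c1c(Cl)cccc1Cl`: 2 ug/mL

Compound 2 stands highest of the two numbers available. Compound 3 lies beyond the scatter below it, the step being a 2.5-fold lower number from compound 2 to compound 3 (0.40 log units; beyond the scatter), brought by hydroxy in place of fluoro on an aromatic carbon. Compound 1 gives only a limit, (the limit of > 100 ug/mL in this assay, at which 1 of the 3 values shown sits).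

The untested compound 4 `O=C1/C(=C\c2ccccc2Cl)c2ccccc2N1c1c(Cl)cccc1Cl` differs from compound 2 by 2-chlorophenyl in place of 4-fluorophenyl on a double-bonded chain carbon bound to a double-bonded ring carbon. Among the measured compounds shown here, no measured step exchanges fluoro for chloro or sets 2-chlorophenyl against 4-fluorophenyl. For the measured compounds named here, the one step available, a 2.5-fold lower number from compound 2 to compound 3 (0.40 log units; beyond the scatter), bears on it only indirectly, in showing that a change of the group on this ring moves the read-out by a modest amount. Going by the values given here, with no closer precedent, compound 4 is therefore expected to show a step of a 1.2-fold higher number from compound 2 to compound 4 (0.08 log units; within the scatter), within the scatter or at most a little beyond. The estimate for compound 4 is 6 ug/mL, with a range of 2 ug/mL to 20 ug/mL.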

Compound 4, concentration for half-maximal effect: > 100 ug/mL
Compound 4: only a limit was reported; the forecaster's own chance of this, stated with the estimate: 10%; at least 16-fold (1.22 log units) between middle value and limit.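

In this assay compound 4 gives > 100 ug/mL, which is a limit of the assay and not a number. The aryl group on a double-bonded chain carbon bound to a double-bonded ring carbon can therefore move the read-out much further than the earlier exchange of fluoro for hydroxy indicated: 2-chlorophenyl in place of 4-fluorophenyl gives an at least 20-fold higher number from compound 2 to compound 4 (1.30 log units; beyond the scatter), and 2-chlorophenyl in place of the hydroxy-bearing ring gives an at least 50-fold higher number from compound 3 to compound 4 (1.69 log units; beyond the scatter). This position thus tolerates some aryl groups but not all, and compound 4 joins compound 1 at the top of the measurable range: the limit of > 100 ug/mL in this assay, at which 2 of the 4 values shown sit.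

Since 2-chlorophenyl and 4-fluorophenyl differ in both the halogen and its place on the ring, the compounds shown do not separate these two changes. Going by these compounds, how a phenyl ring bearing an amine or a carboxylic acid would read at this position also remains open.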